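A few compounds are considered here, and "the series" means these few. Any claim that something is new, unique, unknown or untested is made for them only; others in the source may bear on it.

Measured compounds and their values in a functional assay on the whole organism (strain Wistar) for inhibition, with Rattus norvegicus as the target, read by paw edema, with stated times of 1 h and 5 h, at a dose of 20 mg/kg by the oral route; on this read-out higher numbers stand for more inhibition at the one dose given (going by the name of the read-out) and lower numbers for less inhibition:
- compound 1 `NS(=O)(=O)c1ccc2nc(N3N=C(c4ccc(Br)cc4)CC3c3ccc(Cl)cc3)sc2c1` gives 14%
- compound 2 `NS(=O)(=O)c1ccc2nc(N3N=C(c4ccc(Cl)cc4)CC3c3ccccc3)sc2c1` gives 68.3%
- compound 3 `NS(=O)(=O)c1ccc2nc(N3N=C(c4ccc(Cl)cc4)CC3c3cccs3)sc2c1` gives 14%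

Compound 3 stands level with compound 1 at the digits recorded, the two of them together at the bottom of the three numbers; its nearest neighbour is compound 1, with no change at the digits recorded, and its furthest is compound 2, which sits higher by a margin beyond the scatter.

The step under consideration goes from compound 3 to compound 4 `NS(=O)(=O)c1ccc2nc(N3N=C(c4ccc(Cl)cc4)CC3c3ccc(Cl)cc3)sc2c1`, not yet measured in this assay. The change is 4-chlorophenyl in place of thiophen-2-yl on a saturated ring carbon.

Going by the values given here, one measured step bears on it directly: a number 54.3 percentage points lower from compound 2 to compound 3 (beyond the scatter). That step runs in the opposite sense to the present one, an aromatic carbocycle on the saturated ring carbon giving way to the thiophen-2-yl, and it was large. Reversing the exchange, with a 4-chlorophenyl instead of a plain phenyl entering, suggests a rise for compound 4. Compound 1, which also carries a 4-chlorophenyl on the saturated ring carbon but a different ring on the other side, gives only 14%, so the size of the rise is uncertain.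

A rise of roughly a number 21 percentage points higher from compound 3 to compound 4 (beyond the scatter) is expected for compound 4, with considerable spread.

Compound 4 is estimated at 35%, within a range from 10% to 65%.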

Compound 4, a percentage reported as inhibition, in the whole organism at one dose (the size of the read-out at that dose, not a potency): 14%
Estimate against measurement, compound 4: 21 percentage points above; low and high end bracket the measured number.
By their numbers in this assay, from the lowest: compounds 1, 3 and 4 (each within the scatter of the next); then compound 2.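

In this assay, 4-chlorophenyl in place of thiophen-2-yl on the saturated ring carbon gives no change at the digits printed from compound 3 to compound 4 (within the scatter), so the earlier loss, a number 54.3 percentage points lower from compound 2 to compound 3 (beyond the scatter), is not particular to thiophen-2-yl. Chloro in place of hydrogen on an aromatic carbon gives a number 54.3 percentage points lower from compound 2 to compound 4 (beyond the scatter), a step of the same printed size, which leaves the plain phenyl of compound 2 as the only group at this position with a high number among the compounds shown. Chloro in place of bromo on an aromatic carbon gives no change at the digits printed from compound 1 to compound 4 (within the scatter), so that exchange does not separate compound 1 from compound 4, and no measurement given here accounts for any of these steps.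

The shared number of compound 1, compound 3 and compound 4 does not show whether a single dose can separate these compounds any further at this low level. Also open, from the compounds shown here alone, is whether any group other than plain phenyl on the saturated ring carbon, such as 4-methoxyphenyl, 4-fluorophenyl or a short alkyl chain, keeps a number near that of compound 2.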